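Amide substituent variation: outlook for compound 4

A few compounds are considered here, and "the series" means these few. Any claim that something is new, unique, unknown or untested is made for them only; others in the source may bear on it.

Among the measured compounds shown here, compound 3 `O=C(c1nc(-c2cccs2)[nH]c(=O)c1O)N1CCCC1` gives 13700 nM in an assay on isolated protein for inhibition of Flap endonuclease 1 (Homo sapiens) (on this read-out lower numbers stand for stronger inhibition and higher numbers for weaker inhibition), and holds the highest of the three numbers measured so far. Its nearest neighbour is compound 2 `CNC(=O)c1nc(-c2cccs2)[nH]c(=O)c1O`, which gives 12000 nM in this assay; the step of a 1.1-fold higher number from compound 2 to compound 3 (0.06 log units; within the scatter) lies within the scatter. For the measured compounds named here, the furthest is compound 1 `CC(=O)Nc1ccc2[nH]c(=O)n(O)c(=O)c2c1`, built on a different core, which gives 2000 nM in this assay, a lower number than compound 3 by a margin beyond the scatter; no single-place step connects compound 1 to compound 3, so only the two values themselves can be compared.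

Compound 4 `CC(=O)NCCNC(=O)c1nc(-c2cccs2)[nH]c(=O)c1O` differs from compound 3 in one place: (2-acetamidoethyl)amino in place of pyrrolidin-1-yl on a carbonyl carbon. Going by the values given here, the one measured step that bears on this position is a 1.1-fold higher number from compound 2 to compound 3 (0.06 log units; within the scatter), in which exchanging one amide substituent for another left the number unchanged within the scatter. Among the compounds with values here, no measured compound carries the (2-acetamidoethyl)amino group, so its effect in this assay rests on that single precedent alone. On that basis the step of a 1.1-fold lower number from compound 3 to compound 4 (0.06 log units; within the scatter) is expected to remain within the scatter, in either direction. Compound 4 is therefore estimated at 12000 nM in this assay, with a range from 5000 nM to 30000 nM.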

Compound 4, half-maximal inhibitory concentration: 5000 nM
Beside the measured number, compound 4's estimate is 2.4-fold (0.38 log units) above it, within the range that was stated.
By their numbers in this assay, from the lowest: compound 1; then compound 4; then compounds 2 and 3 (each within the scatter of the next).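

In this assay this amide position, on a carbonyl carbon whose other neighbour is an aromatic carbon, turns out to respond to substitution: a 2.7-fold lower number from compound 3 to compound 4 (0.44 log units; beyond the scatter), whereas the exchange of methylamino for pyrrolidin-1-yl gave only a 1.1-fold higher number from compound 2 to compound 3 (0.06 log units; within the scatter). The acetamidomethyl extension of the methylamino group reads in the same direction, with a 2.4-fold lower number from compound 2 to compound 4 (0.38 log units; beyond the scatter), so compound 4 stands apart from both simpler amides by a modest margin, and the position is not indifferent to every substituent. No supporting data on the compounds bear on this shift, and the step stays an observation on the number alone.

Which part of the (2-acetamidoethyl)amino group carries the step remains open, as the chain and its terminal acetamide enter together in compound 4. Also open, as far as these compounds go, is how the number would respond to a plain ethylamino group, to a terminal primary amine or carboxylic acid in place of the acetamide, or to a longer chain between the amide nitrogen and the acetamide.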